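Diaryl urea series: dichlorophenyl swap on the diethylamino analogue

A few compounds are considered here, and "the series" means these few. Any claim that something is new, unique, unknown or untested is made for them only; others in the source may bear on it.

Two members of this diaryl urea series carry a value in a functional assay on MDA-MB-231 cells (Homo sapiens) for antiproliferative activity, read by MTT assay, with a stated time of 72 h; on this read-out lower numbers stand for stronger inhibition and higher numbers for weaker inhibition. Compound 1 `CN(C)CCn1cnnc1-c1cc(Oc2ccc(NC(=O)Nc3ccc(Cl)cc3Cl)cc2F)ccn1` gives 7960 nM. Compound 2 `CCN(CC)CCn1cnnc1-c1cc(Oc2ccc(NC(=O)Nc3ccc(F)c(F)c3)cc2F)ccn1` gives 41300 nM, the higher of the two numbers, set apart from compound 1 by a gap beyond the usual scatter. Compound 1 and compound 2 differ in two places at once, so no single step can be read between them.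

Compound 3 `CCN(CC)CCn1cnnc1-c1cc(Oc2ccc(NC(=O)Nc3ccc(Cl)cc3Cl)cc2F)ccn1` is the next candidate; it differs from compound 2 by 2,4-dichlorophenyl in place of 3,4-difluorophenyl on an amide-type nitrogen, the same aryl group that compound 1 carries. Without a matched step, the expectation for compound 3 rests on compound 1, whose value in this assay is 7960 nM. A step downward, probably beyond the scatter, is expected from compound 2 to compound 3, namely a 3.4-fold lower number from compound 2 to compound 3 (0.54 log units; beyond the scatter). Compound 3 is therefore estimated at 12000 nM, within a range from 4000 nM to 40000 nM.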

Compound 3, half-maximal inhibitory concentration: 1790 nM
Beside the measured number, compound 3's estimate is 6.7-fold (0.83 log units) above it, outside the stated range (below it).
By their numbers in this assay, from the lowest: compound 3; then compound 1; then compound 2.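

In this assay the aryl group on the amide-type nitrogen now has its first matched reading: 2,4-dichlorophenyl in place of 3,4-difluorophenyl gives a 23-fold lower number from compound 2 to compound 3 (1.36 log units; beyond the scatter), so the series responds strongly to this change. The amine end also has its first matched reading, with diethylamino in place of dimethylamino giving a 4.4-fold lower number from compound 1 to compound 3 (0.65 log units; beyond the scatter), a more modest step that shows this end of the chain also affects the read-out. No measurement available here accounts for either step.

As far as these compounds go, each change is read only once, so it remains open whether the aryl step would hold on the dimethylamino chain. From the compounds shown here alone, the effect of a pyrrolidine or morpholine in place of diethylamino, or of a longer chain to the amine, also remains open.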